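Pyrimidinyl amine variant of compound 1 in the series

A few compounds are considered here, and "the series" means these few. Any claim that something is new, unique, unknown or untested is made for them only; others in the source may bear on it.

Compound 1 `CCC[C@@H](NC(=O)c1nccs1)c1cnc(Nc2ccc(C)nc2)c(Cl)c1` is the reference point. In a functional assay on HEK293 cells for negative allosteric modulation of metabotropic glutamate receptor 5 (Homo sapiens), read by HTRF and inositol phosphate accumulation (on this read-out lower numbers stand for stronger inhibition and higher numbers for weaker inhibition), compound 1 gives 8.2 nM, the lowest number among the three measured compounds. Compound 2 `Cc1ccc(Nc2ncc([C@H](NC(=O)c3nccs3)C3CC3)cc2Cl)cn1` gives 9.7 nM; the step of a 1.2-fold higher number from compound 1 to compound 2 (0.07 log units; within the scatter) is within the scatter, so the two are not separated. Compound 3 `CCC[C@@H](NC(=O)c1ccccn1)c1cnc(Nc2ccc(C)nc2)c(Cl)c1` gives 27.8 nM; the step of a 3.4-fold higher number from compound 1 to compound 3 (0.53 log units; beyond the scatter) is a modest weakening.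

Compound 4 `CCC[C@@H](NC(=O)c1nccs1)c1cnc(Nc2cnc(C)nc2)c(Cl)c1` differs from compound 1 in one place: 2-methylpyrimidin-5-yl in place of 6-methylpyridin-3-yl on a nitrogen on an aromatic ring. Neither measured step touches this position: one concerns the substituent on the saturated carbon bound to the amide nitrogen, the other the heteroaryl on the carbonyl carbon. Among the compounds with values here, there is thus no direct precedent for exchanging the aryl on the amine nitrogen. What the series shows is that changes elsewhere move the number by a small or modest amount, with no shift beyond that. For compound 4 the expected step is a 1.3-fold higher number from compound 1 to compound 4 (0.13 log units; within the scatter), that is, no change beyond the scatter, with some room for weakening. The estimate for compound 4 is 11 nM, within 4 nM to 35 nM.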

Compound 4, half-maximal inhibitory concentration: 43.9 nM
For compound 4 the middle estimate is 4.0-fold (0.60 log units) below the measured one; the whole stated range lies below it.
By their numbers in this assay, from the lowest: compounds 1 and 2 (each within the scatter of the next); then compounds 3 and 4 (each within the scatter of the next).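

In this assay, the aryl group on the amine nitrogen proves to be a position where a single exchange moves the number: 2-methylpyrimidin-5-yl in place of 6-methylpyridin-3-yl gives a 5.4-fold higher number from compound 1 to compound 4 (0.73 log units; beyond the scatter). The step is a weakening, although the two groups are alike in much of what is counted: each has 7 heavy atoms and one six-membered aromatic ring, while the entering group has 2 hetero atoms and 2 hydrogen-bond acceptors where the leaving group has 1 of each. No measurement at hand accounts for the weakening.

From the compounds shown here alone, whether a phenyl or an unsubstituted pyridin-3-yl group on this nitrogen would bring the number closer to that of compound 1 remains open. Also open, going by these compounds, is whether the same exchange weakens inhibition to a similar extent with the cyclopropyl group of compound 2 or the pyridin-2-yl amide of compound 3.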